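The source may report more compounds than this note shows. Statements on the series, on what has been measured and on what is new or still open speak of the compounds shown alone.

Compound 1 `Cc1cc(C(=O)O)ccc1CN1CCC[C@H](O[C@H](CF)c2cc(Cl)cc(Cl)c2)[C@@H]1c1ccccc1` is one of two compounds for which a number exists in an assay on isolated protein for activation of cGMP-dependent protein kinase 1 (Homo sapiens), read by ADP-Glo, with stated times of 30 min and 2 h; on this read-out lower numbers stand for an effect already at smaller amounts and higher numbers for an effect only at larger amounts of compound. In this assay compound 1 gives 20000 nM, the lower of the two numbers. Compound 2 `COC(=O)Nc1cc(C(=O)O)ccc1CN1CCC[C@H](O[C@H](CO)c2cc(Cl)cc(Cl)c2)[C@@H]1c1ccccc1`, which carries a different substituent on the aromatic acid and a different side chain on the ether oxygen, gives 69000 nM in this assay, a gap that lies beyond the usual scatter, so compound 1 stands as the better of the pair.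

Compound 3 `Cc1cc(C(=O)O)ccc1CN1CCC[C@H](OC(c2cc(Cl)cc(Cl)c2)C(C)O)[C@@H]1c1ccccc1` has not yet been measured in this assay. It differs from compound 1 in one place: a group of 12 heavy atoms (9 carbon, 1 oxygen, 2 chlorine; one six-membered aromatic ring of carbon only) in place of a group of 11 heavy atoms (8 carbon, 1 fluorine, 2 chlorine; one six-membered aromatic ring of carbon only), on an oxygen on a saturated carbon. Going by the values given here, no pair of measured compounds shows this change on its own, so its size can only be guessed. The one hint available is that compound 2, whose side chain also carries an oxygen as donor and acceptor, gives 69000 nM, and that compound 1, without such an oxygen, gives 20000 nM; whether that gap comes from the side chain or from the aromatic substituent cannot be told apart here. The step from compound 1 to compound 3 is therefore expected to be small, a 1.5-fold higher number from compound 1 to compound 3 (0.18 log units; within the scatter), possibly toward a higher number. For compound 3 the estimate in this assay is 30000 nM, with a range from 10000 nM to 90000 nM.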

Compound 3, half-maximal effective concentration: > 196000 nM
Compound 3: only a limit was reported; the forecaster's own chance of this, stated with the estimate: 20%; middle value at least 6.5-fold (0.81 log units) from the limit.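

Compound 3 gives no number in this assay, only a limit: the limit of > 196000 nM in this assay, at which 1 of the 3 values shown sits. At this place, on an oxygen on a saturated carbon, the group of 12 heavy atoms with 1 hydrogen-bond donor and 1 hydrogen-bond acceptor, in place of the group of 11 heavy atoms with neither, gives an at least 9.8-fold higher number from compound 1 to compound 3 (0.99 log units; beyond the scatter). Going by these compounds alone, compound 2 differs from compound 1 in more than one place and could not show this, so this step is the first sign that a change at this place alone, with the rest of compound 1 untouched, moves the read-out beyond the scatter.

The change swaps fluorine for oxygen, adds a carbon and replaces a group with 1 defined stereocentre by one with none listed, and the compounds shown do not tell which of these matters. They also leave open how an amine, a methoxy group or a longer chain at this place would compare with the group in compound 1.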